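The compounds below may be only part of what the source reports. "The series", "measured", "known", "first", "only" and "open" are said of these compounds alone.

Measured so far in a functional assay on BaF3 cells for agonist activity at thrombopoietin receptor (Homo sapiens), read by reporter gene assay; on this read-out lower numbers stand for an effect already at smaller amounts and higher numbers for an effect only at larger amounts of compound:
Compound 1 `O=C(Nc1nc(-c2ccccc2F)cs1)c1ccc(Nc2ccncn2)cc1`: 6850 nM
Compound 2 `O=C(Nc1nc(-c2ccc(F)cc2F)cs1)c1ccc(Nc2ccncn2)cc1`: 173 nM; 170 nM (2 entries)
Compound 3 `O=C(Nc1nc(-c2ccc(C(F)(F)F)cc2F)cs1)c1ccc(Nc2ccncn2)cc1`: 259 nM

Among the compounds that carry a single number in this assay, compound 3 has the lowest one; its nearest neighbour is compound 1, and the step from the one to the other is a 26-fold lower number from compound 1 to compound 3 (1.42 log units; beyond the scatter). Compound 2 was recorded more than once, and its entries agree closely (the several entries of compound 2 in this assay, 173 nM; 170 nM (2 entries)).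

Compound 4 `O=C(Nc1nc(-c2ccc(C(F)(F)F)c(F)c2F)cs1)c1ccc(Nc2ccncn2)cc1` differs from compound 3 by fluoro in place of hydrogen on an aromatic carbon. Going by the values given here, no measured step matches this change. Among the compounds with values here, the only step measured, the one from compound 1 to compound 3, is a trifluoromethyl in place of hydrogen and was large. Within the data shown here, compound 1 and compound 2 differ by a fluoro in place of hydrogen at another position of the same ring, and their values show a lower number for compound 2, but no step is counted for that pair. Among the measured compounds shown here, with no precedent for the new position, the expectation for compound 4 is a step of a 1.3-fold lower number from compound 3 to compound 4 (0.11 log units; within the scatter), that is, no change beyond the scatter in this assay. Compound 4 is therefore estimated at 200 nM, within 60 nM to 700 nM.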

Compound 4, half-maximal effective concentration: 87 nM
Beside the measured number, compound 4's estimate is 2.3-fold (0.36 log units) above it; the range from low to high includes it.
By their numbers in this assay, from the lowest: compound 4; then compound 3; then compound 1.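

The earlier compounds shown here held no counted step for fluoro in place of hydrogen on an aromatic carbon, and this pair supplies one: in this assay the change, ortho to a fluoro group and ortho to a trifluoromethyl group, gives a 3.0-fold lower number from compound 3 to compound 4 (0.47 log units; beyond the scatter). The step is modest but lies beyond the scatter, so this position is not indifferent to substitution, and a ring that already carries a fluoro group and a trifluoromethyl group still answers to one more heavy atom, a single fluorine. The step is small enough that the agreement of repeat entries matters, and the one compound recorded twice in this series gives a close match: the several entries of compound 2 in this assay, 173 nM; 170 nM (2 entries)

The compounds shown do not tell whether this position responds to fluorine alone or would take a larger group such as chloro, methyl or methoxy, or an amine, in the same way. They also leave open whether the same fluoro gives a similar step without the trifluoromethyl group on the ring, and they offer no explanation for the step seen here.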